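This account rests on a few compounds, and the source may have more. Where it says the series, first, only, none or still open, it means among the compounds named here.

Measured compounds:
Compound 1 `CCCSc1nc(N/N=C/c2ccc(C)cc2)c2nnn(Cc3ccccc3)c2n1` gives > 64000 nM in a functional assay on MCF7 cells (Homo sapiens) for antiproliferative activity, read by MTT assay, with a stated time of 72 h (a higher number here means a weaker inhibitor, a lower number a stronger inhibitor), and this is a limit of the assay rather than a number.
Compound 2 `C#CCSc1nc(N/N=C(\C)c2ccccc2O)c2nnn(Cc3ccccc3)c2n1` gives 11300 nM in this assay.
Compound 3 `CCCSc1nc(N/N=C(\C)c2ccccc2O)c2nnn(Cc3ccc(F)cc3)c2n1` gives > 64000 nM in this assay, again a limit rather than a number.

Compound 1 therefore stands at the limit of > 64000 nM in this assay, at which 2 of the 3 values shown sit, so only a boundary is known for it and no measured value. Compound 4 `CCCSc1nc(N/N=C/c2ccccc2F)c2nnn(Cc3ccccc3)c2n1` differs from compound 1 by 2-fluorophenyl in place of 4-methylphenyl on a carbon with a double bond to nitrogen. Within the data shown here, no measured pair of compounds differs in only one place, so the data give no size for a step of this kind. The step is expected to be small, not beyond the usual scatter, a step that the limit leaves unreadable from compound 1 to compound 4. Compound 4 is expected to give about 80000 nM in this assay, in a range from 20000 nM to 300000 nM, most likely reported once more as a limit.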

Compound 4, half-maximal inhibitory concentration: > 64000 nM
Compound 4: a limit, no number (the forecaster's own chance of this, stated with the estimate: 70%); the middle value is on the limit's open side.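

Compound 1 and compound 4 both give only a limit in this assay, so the step between them cannot be read: the limit of > 64000 nM in this assay, at which 3 of the 4 values shown sit.

As far as these compounds go, whether 2-fluorophenyl in place of 4-methylphenyl changes the activity at all remains open.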